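From Ethynyl to Thiophen-2-yl on Compound 1

The source may hold more compounds than are shown below. What is called first, only, known or untested is meant among the compounds shown, and "the series" means these compounds.

Of the compounds shown here, three have been measured in a functional assay on HepG2 cells (Homo sapiens) for antiproliferative activity, read by XTT assay, with a stated time of 72 h; on this read-out lower numbers stand for stronger inhibition and higher numbers for weaker inhibition. Compound 1, `C#Cc1cn([C@@H]2O[C@H](CO)[C@@H](O)[C@H]2O)c2ncnc(C)c12`, gives 290 nM and holds the lowest of the two full numbers recorded. Compound 2, `C#Cc1cn([C@@H]2O[C@H](CO)[C@@H](O)[C@H]2O)c2ncnc(N(C)C)c12`, gives 1320 nM; dimethylamino in place of methyl on an aromatic carbon brings a 4.6-fold higher number from compound 1 to compound 2 (0.66 log units; beyond the scatter). Compound 3, `C#Cc1cn([C@@H]2O[C@H](CO)[C@@H](O)[C@H]2O)c2ncnc(NC)c12`, reaches only the limit of this assay, > 15000 nM, so no number is known for it. Measured from compound 1 that means an at least 51-fold higher number from compound 1 to compound 3 (1.71 log units; beyond the scatter), and the change of hydrogen in place of methyl on a nitrogen on an aromatic ring gives an at least 11-fold higher number from compound 2 to compound 3 (1.05 log units; beyond the scatter). All three steps concern the group on an aromatic carbon of the shared core and the amine built on it.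

Compound 4, `Cc1ncnc2c1c(-c1cccs1)cn2[C@@H]1O[C@H](CO)[C@@H](O)[C@H]1O`, is not yet measured. It differs from compound 1 elsewhere: thiophen-2-yl in place of ethynyl on an aromatic carbon. For the measured compounds named here, none of the measured steps alters the ethynyl group, so none bears directly on the step ahead; the only anchor is the number for compound 1. In this assay compound 4 is therefore expected to give a value not far from the parent value, with a wide range, and the expected step is a 2.1-fold higher number from compound 1 to compound 4 (0.32 log units; beyond the scatter). The estimated value for compound 4 is 600 nM, between 100 nM and 4000 nM.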

Compound 4, half-maximal inhibitory concentration: > 15000 nM
Compound 4 gave a limit, no number; the forecaster's own chance of this, stated with the estimate: 10%; at least 25-fold (1.39 log units) between middle value and limit.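

Until now only the group on the other aromatic carbon of the shared core had changed, while ethynyl stayed in place. In this assay, putting thiophen-2-yl in place of ethynyl brings an at least 51-fold higher number from compound 1 to compound 4 (1.71 log units; beyond the scatter), which shows that the antiproliferative activity of compound 1 also depends on what sits at this second position, two ring bonds from the ring nitrogen. Compound 4 stands at a limit of the assay and not at a number, so this step gives only a floor and its true size stays unknown: the limit of > 15000 nM in this assay, at which 2 of the 4 values shown sit.

The change replaces 2 heavy atoms with no ring by 5 heavy atoms in a five-membered aromatic ring that holds sulfur, and a single pair cannot tell which of these differences counts. From the compounds shown here alone, it remains open whether a nitrile, a chlorine atom or a propyl chain at this position would keep a full number close to that of compound 1, and whether thiophen-2-yl would behave the same way on a core carrying dimethylamino in place of methyl.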